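Trimming the Thioether Arm: From Benzyl to Propyl

A few compounds are considered here, and "the series" means these few. Any claim that something is new, unique, unknown or untested is made for them only; others in the source may bear on it.

Of the compounds shown here, two have been measured in a functional assay on HeLa cells (Homo sapiens) for antiproliferative activity, read by CCK-8 assay, with a stated time of 48 h; on this read-out lower numbers stand for stronger inhibition and higher numbers for weaker inhibition. Compound 1 `O=c1c2ccccc2[se]n1-c1nc(SCc2ccc(Cl)cc2)n[nH]1` gives 40900 nM. Going by the values given here, compound 2 `Cc1ccccc1CSc1n[nH]c(-n2[se]c3ccccc3c2=O)n1` gives 6130 nM, the lowest of the two numbers, and the only measured step, a 6.7-fold lower number from compound 1 to compound 2 (0.82 log units; beyond the scatter), shows a modest improvement on swapping one aromatic group for another.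

Compound 3 `CCCSc1n[nH]c(-n2[se]c3ccccc3c2=O)n1` is the next variation. Its difference from compound 2 is ethyl in place of 2-methylphenyl on a saturated chain carbon bound to a sulfur, so the aromatic ring that carried the methyl group is gone and a short chain stands in its place. Among the compounds with values here, the step from compound 1 to compound 2 only compared two substituted aromatic rings; no measured step shows what happens when the ring is removed altogether, so the bearing of that step on compound 3 is indirect at best. With nothing to suggest a gain, a small loss in potency is the more cautious expectation.

Compound 3 is therefore expected to give about 12000 nM, within a range of 4000 nM to 40000 nM, which amounts to an estimated step of a 2.0-fold higher number from compound 2 to compound 3 (0.29 log units; within the scatter).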

Compound 3, half-maximal inhibitory concentration: 30400 nM
For compound 3 the middle estimate is 2.5-fold (0.40 log units) below the measured one; low and high end bracket the measured number.
By their numbers in this assay, from the lowest: compound 2; then compounds 3 and 1 (each within the scatter of the next).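

Removing the aromatic ring has a clear cost when the starting point is compound 2: ethyl in place of 2-methylphenyl on a saturated chain carbon bound to a sulfur gives a 5.0-fold higher number from compound 2 to compound 3 (0.70 log units; beyond the scatter) in this assay. Having an aromatic ring at this place is still not enough by itself, since ethyl in place of 4-chlorophenyl gives a 1.3-fold lower number from compound 1 to compound 3 (0.13 log units; within the scatter), which leaves compound 1, with its ring, level with ringless compound 3 and so goes against any simple rule that a ring here helps. Among these three compounds, the stronger inhibition therefore belongs to the 2-methylphenyl group of compound 2 rather than to aromatic rings in general, and no supporting data are available to explain this difference.

These compounds leave open whether the gain in compound 2 depends on the methyl group, which a plain phenyl or a 2-chlorophenyl group at the same place could test. They also leave open how a longer chain such as hexyl, or a chain ending in an amine or a carboxylic acid, would compare with ethyl.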